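The source may hold more compounds than are shown below. What is called first, only, known or untested is meant among the compounds shown, and "the series" means these compounds.

Among the measured compounds shown here, compound 1, with the structure `CSc1nc(-c2cccc(O)c2)c2c(N)c(C(=O)NC(C)(C)C)sc2n1`, is the only member of this small set for which a number exists: in a functional assay on HEK293 cells for agonist activity at lutropin-choriogonadotropic hormone receptor (Homo sapiens), read by cAMP accumulation (on this read-out higher numbers stand for an effect only at larger amounts of compound and lower numbers for an effect already at smaller amounts), compound 1 gives 1900 nM. Compound 2, with the structure `COc1cccc(-c2nc(SC)nc3sc(C(=O)NN)c(N)c23)c1`, shares the core of compound 1 but carries a methoxy-substituted phenyl and an aminocarbamoyl group, and in this assay the result for compound 2 is "not determined" (no result reported), so no number fixes where compound 2 stands. Compound 3, with the structure `COc1cccc(-c2nc(SC)nc3sc(C(=O)OC(C)(C)C)c(N)c23)c1`, differs from compound 2 in one place: tert-butoxy in place of aminoamino on a carbonyl carbon. For the measured compounds named here, no measured pair shows what this kind of change does in this assay, and without a number for compound 2 no direction or size of step can be read from the data. Going by the values given here, what remains is the single value of compound 1 as an anchor. Compound 3 is therefore expected to lie near 2000 nM in this assay, within a wide range from 300 nM to 15000 nM.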

Compound 3, half-maximal effective concentration: 1100 nM
Compound 3: the middle estimate sits 1.8-fold (0.26 log units) above what was measured, and the stated range covers the measured number.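

Among the compounds shown here, compound 2 has no number in this assay and so no step to compound 3 at 1100 nM can be read. The compounds shown leave open what the change from aminocarbamoyl to tert-butoxycarbonyl does on this read-out. No other evidence bears on this result.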